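Methyl capping of the phenol on the pendant aryl ring

This account rests on a few compounds, and the source may have more. Where it says the series, first, only, none or still open, it means among the compounds named here.

Measured so far:
compound 1 `COc1ccc(-c2cc3ccccc3c(-c3cccc(OC)c3)n2)cc1`: in a functional assay on T47D cells (Homo sapiens) for cytotoxicity, read by CCK-8 assay and cell counting, with a stated time of 72 h (a higher number here means a weaker inhibitor, a lower number a stronger inhibitor), compound 1 gives 860 nM
compound 2 `COc1ccc(-c2cc3ccccc3c(-c3ccc(O)cc3)n2)cc1`: in this assay compound 2 gives 1220 nM

Among the measured compounds shown here, compound 2 carries a 4-hydroxyphenyl group on the shared core and sits at the upper end of the two numbers so far, but its only neighbour is compound 1, and the step of a 1.4-fold higher number from compound 1 to compound 2 (0.15 log units; within the scatter) is within the scatter, so the two compounds cannot be separated on these data.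

Compound 3 `COc1ccc(-c2cc3ccccc3c(-c3ccc(OC)cc3)n2)cc1` is the next member. The change from compound 2 is methyl in place of hydrogen on an oxygen on an aromatic ring, that is, hydroxy to methoxy, 4-hydroxyphenyl to 4-methoxyphenyl. For the measured compounds named here, no measured step is of exactly this kind. Going by the values given here, the one step that bears on it, the swap of 3-methoxyphenyl for 4-hydroxyphenyl between compound 1 and compound 2, is a 1.4-fold higher number from compound 1 to compound 2 (0.15 log units; within the scatter), within the scatter, which argues that substituent variation on this ring has so far moved this assay little. Compound 3 is therefore expected to show no step beyond the scatter, with a 1.3-fold lower number from compound 2 to compound 3 (0.11 log units; within the scatter) as the estimated shift, perhaps leaning toward the number of compound 1. The estimate for compound 3 in this assay is 950 nM, with a range from 400 nM to 2300 nM.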

Compound 3, half-maximal inhibitory concentration: 850 nM
The estimate for compound 3 lay 1.1-fold (0.05 log units) above the measured number; the range from low to high includes it.
By their numbers in this assay, from the lowest: compounds 3, 1 and 2 (each within the scatter of the next).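

In this assay, methyl in place of hydrogen on the oxygen of the aromatic ring gives a 1.4-fold lower number from compound 2 to compound 3 (0.16 log units; within the scatter), so hydroxy and methoxy on this ring cannot be told apart on these data. The comparison of 4-methoxyphenyl with 3-methoxyphenyl gives a 1.0-fold lower number from compound 1 to compound 3 (0.01 log units; within the scatter), so these two forms of the methoxyphenyl group cannot be separated either. With this result, compound 1, compound 2 and compound 3 all lie within the scatter of one another, and none of the three single changes on this ring gives a readable shift in this assay. No available evidence bears on why these numbers stay so close.

Open, going by these compounds, is whether this ring gives any readable shift with a group other than hydroxy or methoxy, such as an amine, a carboxylic acid or a longer chain like butoxy in place of methoxy. The second 4-methoxyphenyl group on the shared core is the same in compound 1, compound 2 and compound 3, so these numbers say nothing about replacing it, for example with a 4-aminophenyl group.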